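The source may hold more compounds than are shown below. What is called first, only, known or untested is meant among the compounds shown, and "the series" means these compounds.

Working notes on the series. Compound 1 `COc1ccccc1C(=O)NCCNc1cccc(NS(=O)(=O)c2cc(-c3cccc(C(=O)N(C)C)c3)ccc2OC)c1` is the reference point for this set: in a functional assay on CHO-K1 cells for agonist activity at Orexin receptor type 2 (Homo sapiens), read by calcium flux (on this read-out higher numbers stand for larger maximal responses and lower numbers for smaller maximal responses), compound 1 gives 74%. Among the compounds with values here, compound 2 `COc1ccc(-c2cccc(C(=O)N(C)C)c2)cc1S(=O)(=O)Nc1cccc(NCCNC(=O)c2ccccc2)c1` carries the same core and the same linker, with a plain benzamide end group in place of the methoxy-bearing one of compound 1; in this assay compound 2 gives "not active" (no number reported), so no single number stands for compound 2 and no numerical step from compound 2 can be computed. The two results side by side show a clear response for compound 1 and none reported for compound 2.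

Compound 3 `COc1cccc(C(=O)NCCNc2cccc(NS(=O)(=O)c3cc(-c4cccc(C(=O)N(C)C)c4)ccc3OC)c2)c1` is the next member to be run in this assay. The change from compound 2 to compound 3 is methoxy in place of hydrogen on an aromatic carbon. Since compound 2 carries no number, the expected step is given as direction only: a methoxy on this ring is present in the responsive compound 1 and absent in compound 2, so a move toward a measurable maximal response is expected, of uncertain size, with a real chance that compound 3 again returns only an inactive call. The estimate for compound 3 in this assay is 40%, with a range of 5% to 80%.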

Compound 3, largest response reached (Emax), in percent of the reference or control that the assay uses: 54%
Compound 3: the middle estimate sits 14 percentage points below what was measured; the range from low to high includes it.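

Within the data shown here, a methoxy on the end group gives a measurable response at a second ring place: in this assay compound 3, with its 3-methoxyphenyl, gives 54% while compound 2, with plain phenyl, gives "not active" (no number reported) as its result, and no numerical step from compound 2 can be read. Both compounds with a methoxy on this ring therefore carry a number, and the one compound shown without it carries none. The place of the methoxy also matters for the size of the response, as 3-methoxyphenyl in place of 2-methoxyphenyl gives a number 20 percentage points lower from compound 1 to compound 3 (beyond the scatter) on the same read-out, and nothing shown here offers a reason for either result.

The compounds shown leave open whether the response needs a methoxy as such or would also appear with another group on this ring, such as a hydroxyl, an ethoxy or a chlorine. Also open, going by these compounds, is how a longer chain in the linker, or an amine on the end group, would alter the maximal response in this assay for a compound carrying either 2-methoxyphenyl or 3-methoxyphenyl.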